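A few compounds are considered here, and "the series" means these few. Any claim that something is new, unique, unknown or untested is made for them only; others in the source may bear on it.

Measured compounds in hand:
Compound 1 `CCCCN(C)c1cc(C(F)(F)F)ccc1CNC(=O)C(C)c1ccc(NS(C)(=O)=O)c(F)c1` gives 1.2 nM in an assay on CHO cells for antagonist activity at transient receptor potential cation channel subfamily V member 1 (Homo sapiens), read by FLIPR; a higher number here means a weaker inhibitor, a lower number a stronger inhibitor.
Compound 2 `CC(C(=O)NCc1ccc(C(F)(F)F)cc1N1CCC(C(F)(F)F)CC1)c1ccc(NS(C)(=O)=O)c(F)c1` gives 0.4 nM in this assay.
Compound 3 `CC(C)COc1cc(C(F)(F)F)ccc1CNC(=O)C(C)c1ccc(NS(C)(=O)=O)c(F)c1` gives 0.8 nM in this assay.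

Compound 3 holds the second highest of the three numbers. Its nearest neighbour is compound 1, the gap being a 1.5-fold lower number from compound 1 to compound 3 (0.18 log units; within the scatter); the furthest is compound 2, with a 2.0-fold higher number from compound 2 to compound 3 (0.30 log units; within the scatter). Both gaps stay within the scatter, so the three measured compounds are not cleanly separated at this position.

Compound 4 `CC(C(=O)NCc1ccc(C(F)(F)F)cc1OCc1ccc(F)cc1)c1ccc(NS(C)(=O)=O)c(F)c1` is the next member of the series. The change from compound 3 reads (4-fluorophenyl in place of isopropyl on a saturated chain carbon bound to an oxygen on an aromatic ring). All three measured steps alter the group on the same aromatic carbon: a 3.0-fold lower number from compound 1 to compound 2 (0.48 log units; beyond the scatter), a 1.5-fold lower number from compound 1 to compound 3 (0.18 log units; within the scatter) and a 2.0-fold higher number from compound 2 to compound 3 (0.30 log units; within the scatter). Only the first of these crosses the scatter, and then only modestly. Swapping an open chain for a ring, or one chain for another, has so far moved the number little. Relative to compound 3, compound 4 is expected to show no change at the digits printed from compound 3 to compound 4 (within the scatter), a move not clearly beyond the scatter. The expected value for compound 4 in this assay is 0.8 nM, with a range from 0.3 nM to 2.5 nM.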

Compound 4, inhibition constant: 0.5 nM
For compound 4 the middle estimate is 1.6-fold (0.20 log units) above the measured one; the measured number falls inside the stated range.
By their numbers in this assay, from the lowest: compounds 2, 4, 3 and 1 (each within the scatter of the next, the first and the last beyond it).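

In this assay, the isobutoxy chain at this aromatic carbon can end in a 4-fluorophenyl ring rather than an isopropyl group without a change that can be read, with a 1.6-fold lower number from compound 3 to compound 4 (0.20 log units; within the scatter). The (4-fluorobenzyl)oxy group also stays within the scatter of the 4-(trifluoromethyl)piperidin-1-yl group, with a 1.3-fold higher number from compound 2 to compound 4 (0.10 log units; within the scatter), so an aromatic ring reached through oxygen and a saturated ring attached through nitrogen cannot be told apart at this carbon. Against butyl(methyl)amino, the same group gives a 2.4-fold lower number from compound 1 to compound 4 (0.38 log units; beyond the scatter), a modest step beyond the scatter; compound 2 and compound 4 therefore both stand clear of compound 1, while compound 3, which shares the ether link with compound 4, does not.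

No evidence bears on why this aromatic ring is accepted at this position. Open questions are whether the fluorine contributes anything, which a plain benzyloxy group would test, and whether the same tolerance extends to a chain ending in a primary amine or a carboxylic acid.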